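Methoxy for Trifluoromethyl: Cytotoxicity Notes on Two Cores

The source may report more compounds than this note shows. Statements on the series, on what has been measured and on what is new or still open speak of the compounds shown alone.

Compound 1 `C/C(=N\NC(N)=O)c1ccc2[nH]c(-c3ccc(C(F)(F)F)cc3)nc2c1`: in an ADME assay on MDBK cells (Bos taurus) for cytotoxicity, read by MTT assay, with a stated time of 96 h (a lower number here means that less compound is tolerated, a higher number that more compound is tolerated), compound 1 gives > 100000 nM, a limit of the assay and not a number.
Compound 2 `COc1ccc(-c2nc3cc(/C(C)=N/NC(N)=O)ccc3[nH]2)cc1`: in this assay compound 2 gives 25000 nM.
Compound 3 `CC(=O)c1ccc2c(c1)nc(-c1ccc(C(F)(F)F)cc1)n2C1CCCCC1`: in this assay compound 3 gives 52000 nM.

Compounds 1 and 2 share one core; compound 2 carries methoxy in place of trifluoromethyl on an aromatic carbon. That change gave an at least 4.0-fold lower number from compound 1 to compound 2 (0.60 log units; beyond the scatter). The true size of the step is open at the top because compound 1 sits at the limit of > 100000 nM in this assay, at which 1 of the 3 values shown sits.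

Compound 3 belongs to a second core; the difference between the two cores is not broken down here. Among the measured numbers compound 3 stands highest, with compound 2 the nearest.

Compound 4 `COc1ccc(-c2nc3cc(C(C)=O)ccc3n2C2CCCCC2)cc1` is not yet measured and carries methoxy in place of trifluoromethyl on an aromatic carbon relative to compound 3. Among the measured compounds shown here, this is the same change as the one from compound 1 to compound 2, at a place described in the same words. For compound 4 a step of a 3.5-fold lower number from compound 3 to compound 4 (0.54 log units; beyond the scatter) is expected in this assay, resting on an at least 4.0-fold lower number from compound 1 to compound 2 (0.60 log units; beyond the scatter), which is itself only a lower bound for the movement. For compound 4 a value near 15000 nM is estimated, between 6000 nM and 40000 nM.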

Compound 4, half-maximal cytotoxic concentration: > 100000 nM
Compound 4 was reported as a limit; the forecaster's own chance of this, stated with the estimate: 5%; middle value at least 6.6-fold (0.82 log units) away from the limit.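

Compound 4 gives > 100000 nM in this assay, a limit of the assay and not a number. On the core of compound 3, methoxy in place of trifluoromethyl on an aromatic carbon gives an at least 1.9-fold higher number from compound 3 to compound 4 (0.28 log units; that floor lies within the scatter), so the direction seen on the core of compound 1 did not carry over: the same change on two cores in this assay, an at least 4.0-fold lower number (0.60 log units; beyond the scatter) from compound 1 to compound 2 and an at least 1.9-fold higher number (0.28 log units; that floor lies within the scatter) from compound 3 to compound 4, at least 7.6-fold (0.88 log units) apart, beyond the scatter of two such steps

For these two pairs, a step read on one core therefore gave no reliable guide to the other, but this does not show a cause, and the full size of both steps remains open because each pair has one member at the assay limit: the limit of > 100000 nM in this assay, at which 2 of the 4 values shown sit.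

Still open, from the compounds shown here alone, is whether the same split between the two cores would appear with an amine or a carboxylic acid on that aromatic carbon in place of trifluoromethyl. Also open, going by these compounds, is which structural difference between the two cores goes with the opposing steps, and no single change links the two cores here.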